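The source may hold more compounds than are shown below. What is called first, only, known or untested is meant among the compounds shown, and "the series" means these compounds.

In a functional assay on the whole organism with Rattus norvegicus as the target (a lower number here means that less compound is needed, a higher number that more compound is needed for the effect), compound 2 `COc1cc(N(C)C)c(Cl)cc1C(=O)NC1CCN(Cc2ccccc2)C1` gives 0.12 mg/kg, the lowest number of the three measured. Compound 3 `COc1cc(N(C)C)c(Cl)cc1C(=O)NC1CCN(C2CCCCC2)C1` gives 1 mg/kg, and compound 1 `CCN(CCNC(=O)c1cc(Cl)c(N)cc1OC)Cc1ccc(Cl)cc1Cl` gives 10 mg/kg. Compound 4 `COc1cc(N2CCCC2)c(Cl)cc1C(=O)NC1CCN(Cc2ccccc2)C1` differs from compound 2 at one place, with pyrrolidin-1-yl in place of dimethylamino on an aromatic carbon. Within the data shown here, no measured step touches that place. Among the measured compounds shown here, the one measured step, an 8.3-fold higher number from compound 2 to compound 3 (0.92 log units; beyond the scatter), sits on an amine nitrogen in a ring, so it bears only indirectly. Compound 2 at 0.12 mg/kg already stands lowest, so a small move toward a higher number is expected, within or just beyond the scatter. The estimate is a 1.7-fold higher number from compound 2 to compound 4 (0.22 log units; within the scatter). Compound 4 is expected at 0.2 mg/kg, within an estimated range of 0.06 mg/kg to 0.7 mg/kg.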

Compound 4, dose for half-maximal effect: 0.6 mg/kg
Beside the measured number, compound 4's estimate is 3.0-fold (0.48 log units) below it, within the range that was stated.
By their numbers in this assay, from the lowest: compound 2; then compounds 4 and 3 (each within the scatter of the next); then compound 1.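

In this assay, the change from dimethylamino to pyrrolidin-1-yl on this aromatic carbon, ortho to a chloro group, gives a 5.0-fold higher number from compound 2 to compound 4 (0.70 log units; beyond the scatter). This position therefore affects the number, as does the amine nitrogen in a ring, where the cyclohexyl change gives an 8.3-fold higher number from compound 2 to compound 3 (0.92 log units; beyond the scatter). Nothing measured here accounts for the difference between the two groups.

On these data alone, whether piperidin-1-yl or a plain amino group at this carbon would stay closer to compound 2 remains open. So does whether the pyrrolidin-1-yl step would hold with cyclohexyl on the ring nitrogen.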